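This account rests on a few compounds, and the source may have more. Where it says the series, first, only, none or still open, it means among the compounds named here.

Measured so far:
compound 1, `Cc1cc(C)c(NC(=O)C(C)(C)CCCOc2ccc(Cl)cc2)c2c1CC(C)(C)O2` — 260 nM
compound 2, `Cc1cc(C)c(NC(=O)C(C)(C)CCCCCOc2ccc(Cl)cc2)c2c1CC(C)(C)O2` — 150 nM

Both compounds share the same core and differ only in the chain that links the amide to the chlorinated aromatic ring. In an assay for inhibition of acyl-CoA:cholesterol acyltransferase (Oryctolagus cuniculus), using microsomes (a lower number here means a stronger inhibitor, a higher number a weaker inhibitor), compound 1 gives 260 nM, and compound 2 gives 150 nM. The step of a 1.7-fold lower number from compound 1 to compound 2 (0.24 log units; within the scatter) lies within the scatter, so compound 2 holds the lower of the two numbers without standing apart from compound 1.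

Compound 3, `Cc1cc(C)c(NC(=O)C(C)(C)CCCCCOc2ccccc2)c2c1CC(C)(C)O2`, keeps the longer chain of compound 2 and changes only the aromatic ring: hydrogen in place of chloro on an aromatic carbon. Among the compounds with values here, no measured step touches this position; the only known step, a 1.7-fold lower number from compound 1 to compound 2 (0.24 log units; within the scatter), concerns the chain length and says nothing about the chloro. With no guide in the data, the expectation is a small step, if any, and the range is set wide. Compound 3 is therefore expected to give 250 nM in this assay, between 90 nM and 700 nM, which means an expected step of a 1.7-fold higher number from compound 2 to compound 3 (0.22 log units; within the scatter).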

Compound 3, half-maximal inhibitory concentration: 86 nM
Beside the measured number, compound 3's estimate is 2.9-fold (0.46 log units) above it; measured number outside the range, below it.
By their numbers in this assay, from the lowest: compounds 3, 2 and 1 (each within the scatter of the next, the first and the last beyond it).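

In this assay, hydrogen in place of chloro on the aromatic carbon gives a 1.7-fold lower number from compound 2 to compound 3 (0.24 log units; within the scatter), so in this pair the chloro is not needed for inhibition at this level. Within the data shown here, compound 3 also gives the first step in this set to lie beyond the scatter, a 3.0-fold lower number from compound 1 to compound 3 (0.48 log units; beyond the scatter), but that step joins two differences, the longer chain and the missing chloro, and neither one alone goes beyond the scatter. No measurement here gives a reason for this result.

Going by these compounds, it remains open whether another group on that aromatic carbon, such as fluoro, methoxy or a carboxylic acid, would keep the number in this range. Among these compounds, it is equally open whether a chain longer than the one in compound 3 would take the number lower still.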